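A few compounds are considered here, and "the series" means these few. Any claim that something is new, unique, unknown or untested is made for them only; others in the source may bear on it.

Measured so far in a functional assay on HepG2 cells (Homo sapiens) for antiproliferative activity, read by CCK-8 assay, with a stated time of 72 h, tested at 2 uM; a lower number here means a weaker effect, a higher number a stronger effect of the compound at the concentration tested:

compound 1 `CN1CCN(c2nc(Cl)nc3c2ncn3Cc2ccc(C(=O)Nc3ccccc3N)cc2)CC1` gives 60.4%
compound 2 `Nc1ccccc1NC(=O)/C=C/c1ccc(Cn2cnc3c(Nc4cccc(Cl)c4)nc(Cl)nc32)cc1` gives 35.8%
compound 3 `CCCCn1cnc2c(Nc3ccccc3)nc(NCOCc3ccc(/C=C/C(=O)Nc4ccccc4N)cc3)nc21` gives 27.9%

Compound 2 stands second highest of the three numbers. Its nearest neighbour is compound 3, whose value lies a little lower but within the scatter; its furthest is compound 1, whose value lies higher by a gap beyond the scatter. Going by the values given here, only these three numbers exist, and none of the three pairs differs in a single place, so no measured step of this kind is known.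

Compound 4 `Nc1ccccc1NC(=O)/C=C/c1ccc(Cn2cnc3c(NCc4ccccc4)nc(Cl)nc32)cc1` is not yet measured in this assay. Against compound 2 it differs in one place:

benzyl in place of 3-chlorophenyl on a nitrogen on an aromatic ring

With nothing comparable to lean on, the expected step is a number 5.8 percentage points lower from compound 2 to compound 4 (within the scatter), a change not beyond the scatter, leaning slightly downward. Compound 4 is estimated at 30%, with a range from 15% to 50%.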

Compound 4, a percentage reported as inhibition, at one concentration (the size of the read-out at that concentration, not a potency): 11.5%
Estimate against measurement, compound 4: 18.5 percentage points above; measured number outside the range, below it.
By their numbers in this assay, from the lowest: compound 4; then compounds 3 and 2 (each within the scatter of the next); then compound 1.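

In this assay, going by these compounds alone, the step of a number 24.3 percentage points lower from compound 2 to compound 4 (beyond the scatter) gives the first one-place reading: the group on this nitrogen matters, even though benzyl and 3-chlorophenyl have the same heavy-atom count. The change removes the chlorine and adds a carbon, and this single step cannot separate the two. No measured evidence accounts for the step.

Open, going by these compounds, is whether unsubstituted phenyl or a longer chain such as 2-phenylethyl on this nitrogen would read closer to compound 2 or compound 4.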